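This account rests on a few compounds, and the source may have more. Where it says the series, first, only, none or still open, it means among the compounds named here.

Measured compounds:
compound 1 `CC1CC(=O)c2s/c(=N/c3ccccc3)oc2C1`: 2980 nM
compound 2 `CC(C)C1CC(=O)c2s/c(=N/c3ccccc3)oc2C1`: 3080 nM
compound 3 `CC1(C)CC(=O)c2s/c(=N/c3ccc(Cl)cc3)oc2C1`: 9810 nM

In a functional assay on ACHN cells (Homo sapiens) for antiproliferative activity, read by sulforhodamine B assay (a lower number here means a stronger inhibitor of growth, a higher number a weaker inhibitor of growth), compound 2 gives 3080 nM, the second highest of the three numbers; compound 1 gives 2980 nM, within the scatter of it, while compound 3 gives 9810 nM. Compound 4 `CC(C)C1CC(=O)c2s/c(=N/c3ccc(F)cc3)oc2C1` differs from compound 2 by fluoro in place of hydrogen on an aromatic carbon. Among the compounds with values here, the only measured single step, a 1.0-fold higher number from compound 1 to compound 2 (0.01 log units; within the scatter), concerns a saturated ring carbon and does not bear on a change at the phenyl. Compound 3 bears a chloro on the phenyl but also differs from compound 2 at the saturated ring, so its two values show only that a halogenated phenyl can go with a higher number. Within the data shown here, with no direct precedent, a small upward step or none beyond the scatter is expected, a 1.4-fold higher number from compound 2 to compound 4 (0.13 log units; within the scatter). Compound 4 is therefore estimated at 4200 nM, between 2000 nM and 9000 nM.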

Compound 4, concentration for 50% growth inhibition: 3670 nM
For compound 4 the middle estimate is 1.1-fold (0.06 log units) above the measured one; the range from low to high includes it.
By their numbers in this assay, from the lowest: compounds 1, 2 and 4 (each within the scatter of the next); then compound 3.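

In this assay, the change from phenyl to 4-fluorophenyl gives a 1.2-fold higher number from compound 2 to compound 4 (0.08 log units; within the scatter), the first single step read at the phenyl rather than at the saturated ring. A fluoro on this aromatic carbon, para to a large group, therefore leaves the number within the scatter. The data shown offer no explanation for this result. On these data alone, whether a methoxy, an amine or a carboxylic acid at this carbon would behave alike remains open. So does how much the chloro and the saturated ring substitution of compound 3 each count.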